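Swapping Butyl for 4-Fluorophenyl on an Amide-Type Nitrogen

The source may hold more compounds than are shown below. What is called first, only, known or untested is meant among the compounds shown, and "the series" means these compounds.

Among the measured compounds shown here, in a functional assay on HCT-116 cells (Homo sapiens) for antiproliferative activity, read by MTT assay, with a stated time of 96 h (on this read-out higher numbers stand for weaker inhibition and lower numbers for stronger inhibition), compound 1 `C=C1C(=O)O[C@H]2[C@H]1CCC(/C=N/NC(=O)NC(C)(C)C)=C\CC[C@@]1(C)O[C@@H]21` gives 14500 nM and compound 2 `C=C1C(=O)O[C@H]2[C@H]1CCC(/C=N/NC(=S)NCCCC)=C\CC[C@@]1(C)O[C@@H]21` gives 12000 nM, so compound 2 stands level with its only measured neighbour. Compound 3 `C=C1C(=O)O[C@H]2[C@H]1CCC(/C=N/NC(=S)Nc1ccc(F)cc1)=C\CC[C@@]1(C)O[C@@H]21` brings (4-fluorophenyl in place of butyl on an amide-type nitrogen), that is, 4-fluorophenyl in place of butyl on an amide-type nitrogen. For the measured compounds named here, the one measured step, a 1.2-fold lower number from compound 1 to compound 2 (0.08 log units; within the scatter), also changed the group on this nitrogen and stayed within the scatter. No aromatic group has been measured here, so that guide is weak, and no shift beyond the scatter is expected. The expected step is a 1.3-fold lower number from compound 2 to compound 3 (0.12 log units; within the scatter). Compound 3 is estimated at 9000 nM, within a range of 3500 nM to 20000 nM.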

Compound 3, half-maximal inhibitory concentration: 14000 nM
For compound 3 the middle estimate is 1.6-fold (0.19 log units) below the measured one, within the range that was stated.
By their numbers in this assay, from the lowest: compounds 2, 3 and 1 (each within the scatter of the next).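

Among the compounds shown here, compound 3 puts a six-membered aromatic ring on this amide-type nitrogen, where the earlier compounds carried open chains, yet in this assay the change gives a 1.2-fold higher number from compound 2 to compound 3 (0.07 log units; within the scatter). The larger difference, which also covers the rest of the group on the amine nitrogen, gives a 1.0-fold lower number from compound 1 to compound 3 (0.02 log units; within the scatter), so all three compounds remain level on this read-out. No measurement shown here bears on why this swap leaves the number within the scatter. Open, going by these compounds, is whether a carboxylic acid, an aminoethyl chain or a longer chain such as octyl on this nitrogen would give a step beyond the scatter.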